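The compounds below may be only part of what the source reports. "The series", "measured", "known", "first", "only" and "open" are said of these compounds alone.

Going by the values given here, in an ADME assay on microsomes from liver (Homo sapiens) for metabolic stability, read by LC-MS, with a stated time of 40 min (a higher number here means that the compound lasts longer, a lower number that the compound disappears faster), compound 1 `Cc1ccc(C(=O)N(CC(=O)NCc2ccccc2)Cc2ccc(C(=O)NO)cc2)c(C)c1` gives 0.328 h, the lower of the two numbers known so far. Compound 2 `CNC(=O)CN(Cc1ccc(C(=O)NO)cc1)C(=O)c1ccc(C(C)C)cc1` gives 5.78 h, and the gap between these two numbers lies beyond the scatter. Compound 3 `Cc1ccc(C(=O)N(CC(=O)NC2CCCCC2)Cc2ccc(C(=O)NO)cc2)c(C)c1` carries cyclohexyl in place of benzyl on an amide-type nitrogen. Among the compounds with values here, no measured pair isolates this change, and compound 2 differs from compound 1 in more than one place. No step beyond the scatter is therefore expected in this assay, with any drift slightly upward. The estimated change is a 1.2-fold higher number from compound 1 to compound 3 (0.09 log units; within the scatter). For compound 3 the expected half-life is 0.4 h, within an estimated range from 0.15 h to 1.2 h.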

Compound 3, half-life: 0.203 h
Beside the measured number, compound 3's estimate is 2.0-fold (0.29 log units) above it; low and high end bracket the measured number.
By their numbers in this assay, from the lowest: compounds 3 and 1 (each within the scatter of the next); then compound 2.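

In this assay, going by these compounds alone, the change of benzyl to cyclohexyl on the amide-type nitrogen gives a 1.6-fold lower number from compound 1 to compound 3 (0.21 log units; within the scatter) and so provides the first step that isolates one place. At this position, an aromatic ring of carbon only and a non-aromatic ring of carbon only therefore cannot be told apart in half-life. Nothing at hand explains this result. Still open, going by these compounds, is whether an amine or a carboxylic acid carried on this nitrogen in place of the ring would give a step beyond the scatter.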